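A few compounds are considered here, and "the series" means these few. Any claim that something is new, unique, unknown or untested is made for them only; others in the source may bear on it.

Of the compounds shown here, three built on one shared core have been tested in a functional assay on KBVIN cells (Homo sapiens) for antiproliferative activity, read by sulforhodamine B assay, with a stated time of 3 days; on this read-out lower numbers stand for an effect already at smaller amounts and higher numbers for an effect only at larger amounts of compound. Compound 1 `CCOc1ccc(-c2cc(=O)c3c(o2)C(CC)(CC)C(=O)C(CC)=C3O)cc1` gives 7.54 uM. Compound 2 `CCC1=C(O)c2c(oc(-c3ccc(OC(F)(F)F)cc3)cc2=O)C(CC)(CC)C1=O` gives 9.95 uM, and compound 3 `CCC1=C(O)c2c(oc(-c3ccccc3C(F)(F)F)cc2=O)C(CC)(CC)C1=O` gives 43.1 uM. Compound 1 holds the lowest of the three numbers: compound 2 lies close to it, while compound 3 stands clearly apart. For the measured compounds named here, the only single-point step on record is a 1.3-fold higher number from compound 1 to compound 2 (0.12 log units; within the scatter), a change of trifluoromethyl in place of ethyl on an oxygen on an aromatic ring that left the number essentially unchanged.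

Compound 4 `CCC1=C(O)c2c(oc(-c3ccc(C)c(C)c3)cc2=O)C(CC)(CC)C1=O` has not yet been measured. It differs from compound 1 in one place: 3,4-dimethylphenyl in place of 4-ethoxyphenyl on an aromatic carbon. Going by the values given here, no measured step swaps 4-ethoxyphenyl for 3,4-dimethylphenyl, so the step from compound 1 to compound 2 is the only guide, and it points to a small movement at most. Compound 4 is therefore expected to show a 1.3-fold higher number from compound 1 to compound 4 (0.12 log units; within the scatter). The estimated value for compound 4 is 10 uM, with a range from 4 uM to 25 uM.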

Compound 4, concentration for half-maximal effect: 0.71 uM
The estimate for compound 4 lay 14-fold (1.15 log units) above the measured number, outside the stated range (below it).
By their numbers in this assay, from the lowest: compound 4; then compounds 1 and 2 (each within the scatter of the next); then compound 3.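

In this assay, the group on this aromatic carbon next to the ring oxygen can move the number well beyond the scatter: an 11-fold lower number from compound 1 to compound 4 (1.03 log units; beyond the scatter). For the compounds shown here, the only earlier single-place step, a 1.3-fold higher number from compound 1 to compound 2 (0.12 log units; within the scatter), changed just the group on the oxygen and kept the 4-substituted phenyl framework, so it could not show how much this position can matter. Here, the oxygen-linked ethyl chain gives way to the two methyl groups of 3,4-dimethylphenyl, and no measured evidence explains the size of this step.

The compounds shown leave open whether both methyl groups are needed, since a phenyl ring carrying a single methyl group is not among them. They also leave open how a ring with an amine or a carboxylic acid in this place would behave.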